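Hydroxy in place of hydrogen on a trimethoxyphenyl benzoxazole

The compounds below may be only part of what the source reports. "The series", "measured", "known", "first", "only" and "open" are said of these compounds alone.

Compound 1 `COc1cc(-c2cccc3nc(-c4ccccc4)oc23)cc(OC)c1OC`: in a functional assay on MCF7 cells (Homo sapiens) for antiproliferative activity, read by MTT assay, with a stated time of 48 h (on this read-out lower numbers stand for stronger inhibition and higher numbers for weaker inhibition), compound 1 gives > 25000 nM, a limit of the assay.
Compound 2 `COc1cc(-c2cccc3nc(-c4cccc(Cl)c4)oc23)cc(OC)c1OC`: compound 2 gives > 25000 nM, again a limit.
Compound 3 `COc1cc(-c2cccc3nc(-c4cccc(C)c4)oc23)cc(OC)c1OC`: compound 3 gives > 25000 nM, again a limit.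

Compound 1 stands only at a limit, as do the other two, and the account rests on (the limit of > 25000 nM in this assay, at which 3 of the 3 values shown sit). The measured steps that touch the same position, a step that the two limits leave unreadable from compound 1 to compound 2 and a step that the two limits leave unreadable from compound 1 to compound 3, are therefore of no readable size and give no direction. Compound 4 `COc1cc(-c2cccc3nc(-c4cccc(O)c4)oc23)cc(OC)c1OC` differs from compound 1 by hydroxy in place of hydrogen on an aromatic carbon. Going by the values given here, no measured step tells whether a hydroxy group changes anything here, so for compound 4 the expected step is a step that the limit leaves unreadable from compound 1 to compound 4, most likely leaving the value near the same limit. The estimate for compound 4 is 30000 nM, in the range from 8000 nM to 100000 nM.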

Compound 4, half-maximal inhibitory concentration: > 25000 nM
Compound 4 ended at the assay's limit (the forecaster's own chance of this, stated with the estimate: 70%); the middle value does not contradict the limit.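

No step can be read between compound 4 and compounds 1, 2 or 3, since all four stand only at a limit: the limit of > 25000 nM in this assay, at which 4 of the 4 values shown sit.

The compounds shown leave open whether any group in this place would give a true number rather than a limit.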